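This account rests on a few compounds, and the source may have more. Where it says the series, first, only, none or still open, it means among the compounds named here.

Measured so far:
compound 1 `Nc1ccccc1NC(=O)c1ccc(CSC(=S)N2CCc3cc([N+](=O)[O-])ccc32)cc1` gives 16.9%
compound 2 `CC1CCCCN1C(=S)SCc1ccc(C(=O)Nc2ccccc2N)cc1` gives 42.5%
compound 3 `COc1ccc(N2CCN(C(=S)SCc3ccc(C(=O)Nc4ccccc4N)cc3)CC2)cc1` gives 28.1%

In a functional assay on A-375 cells (Homo sapiens) for antiproliferative activity, read by CCK-8 assay, with a stated time of 72 h, tested at 2 uM (on this read-out higher numbers stand for a stronger effect at the one concentration tested and lower numbers for a weaker effect), compound 2 gives 42.5%, the highest of the three numbers; compound 3 gives 28.1% and compound 1 gives 16.9%, both lower by margins beyond the scatter. Compound 4 `CN(Cc1ccncc1)C(=S)SCc1ccc(C(=O)Nc2ccccc2N)cc1` is not yet measured. It differs from compound 2 in one place: methyl((pyridin-4-yl)methyl)amino in place of 2-methylpiperidin-1-yl on a thiocarbonyl carbon. For the measured compounds named here, no pair of measured compounds differs by this change alone, so nothing is read directly on it. Because compound 2 stands highest at 42.5% and both other amides fall clearly lower, a downward step of moderate size is expected for compound 4, though it may not clear the scatter. Compound 4 is expected to give about 30%, within 15% to 48%. The step of a number 12.5 percentage points lower from compound 2 to compound 4 (beyond the scatter) is expected to be a drop near the edge of the scatter.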

Compound 4, a percentage reported as inhibition, at one concentration (the size of the read-out at that concentration, not a potency): 31.4%
Compound 4: the middle estimate sits 1.4 percentage points below what was measured; low and high end bracket the measured number.
By their numbers in this assay, from the lowest: compound 1; then compounds 3 and 4 (each within the scatter of the next); then compound 2.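

At the thiocarbonyl carbon, the change to methyl((pyridin-4-yl)methyl)amino in place of 2-methylpiperidin-1-yl gives, in this assay, a number 11.1 percentage points lower from compound 2 to compound 4 (beyond the scatter). For the compounds shown here, this is the first one-place reading at this position, and it shows a modest loss rather than a complete one. No measurement at hand gives a reason for this step.

Still open, as far as these compounds go, is whether the step follows the loss of the 2-methylpiperidin-1-yl group or the entry of the pyridin-4-yl ring. A benzyl(methyl)amino group or an unsubstituted piperidin-1-yl group at this carbon would help separate the two.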